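This account rests on a few compounds, and the source may have more. Where it says the series, first, only, none or still open, it means among the compounds named here.

Working notes on a small set of chloromethyl-benzyl purines tested in a functional assay on NCI-H460 cells (Homo sapiens) for cytotoxicity, read by sulforhodamine B assay, with a stated time of 48 h; a higher number here means that more compound is tolerated, a lower number that less compound is tolerated. Compound 1 `ClCc1cccc(Cn2cnc3ncnc(Cl)c32)c1` gives 91200 nM in this assay. Compound 3 `ClCc1ccc(Cn2cnc3nc(Cl)nc(Cl)c32)cc1`, which carries two chloro groups on its core, gives 79400 nM in this assay. Compound 2 `ClCc1cccc(Cn2cnc3c(Cl)ncnc32)c1` sits differently: in this assay compound 2 gives only > 100000 nM, which is a limit of the assay and not a number, so compound 2 stands at the edge of what can be resolved here, as stated in the limit of > 100000 nM in this assay, at which 1 of the 3 values shown sits.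

The compound to be measured next is compound 4 `ClCc1cccc(Cn2cnc3c(Cl)nc(Cl)nc32)c1`. It differs from compound 2 by chloro in place of hydrogen on an aromatic carbon of the six-membered ring with two nitrogen atoms, between two ring nitrogen atoms and meta to the existing chloro group. Within the data shown here, no step between measured compounds sharing the same benzyl substitution is available to calibrate this change. The step from compound 2 to compound 4 in this assay is expected to be an at least 1.1-fold lower number from compound 2 to compound 4 (0.07 log units; that floor lies within the scatter), at most modest and not clearly beyond the scatter. Compound 4 is estimated at 85000 nM in this assay, within a range of 40000 nM to 200000 nM, with a fair chance that again only a limit is reported.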

Compound 4, concentration lethal to 50% of the cells: > 100000 nM
Compound 4 gave a limit, no number; the forecaster's own chance of this, stated with the estimate: 45%; at least 1.1-fold (0.07 log units) between middle value and limit.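

In this assay compound 2 and compound 4 both give only a limit of the assay and not a number, so no step can be read from one to the other: the limit of > 100000 nM in this assay, at which 2 of the 4 values shown sit.

The compounds shown leave open whether chloro in place of hydrogen on an aromatic carbon shifts the value in this assay at all.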